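A few compounds are considered here, and "the series" means these few. Any claim that something is new, unique, unknown or untested is made for them only; others in the source may bear on it.

Measured compounds in this series:

compound 1, `Nc1cc(N)c2nc(-c3ccccc3)c(Oc3ccc(Cl)c(Cl)c3)nc2c1`, in a functional assay on UACC-257 cells (Homo sapiens) for inhibition, read by sulforhodamine B assay, with a stated time of 48 h (on this read-out higher numbers stand for weaker inhibition of growth and lower numbers for stronger inhibition of growth), gives 28200 nM
compound 2, `CCOC(=O)[C@H](CCC(=O)O)NC(=O)c1ccc(Sc2nc3cc(N)cc(N)c3nc2-c2ccccc2)cc1`, in this assay gives 17400 nM

Compound 1 carries the higher of the two numbers in this assay, but the nearest point, compound 2, lies within the usual scatter of it, so the two cannot be placed in order of growth inhibition. Among the compounds with values here, the two structures differ in more than one place, and no single-change step between measured compounds is available to guide the next one.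

Compound 3, `Nc1cc(N)c2nc(-c3ccccc3)c(Oc3ccc(F)cc3)nc2c1`, differs from compound 1 in one place: 4-fluorophenyl in place of 3,4-dichlorophenyl on an oxygen on an aromatic ring. The rest of the structure is unchanged. Within the data shown here, with no comparable step measured, neither the size nor the direction of the effect can be read from the data. The expected step is a 1.1-fold higher number from compound 1 to compound 3 (0.03 log units; within the scatter), which is not beyond the scatter. Compound 3 is accordingly expected to give about 30000 nM in this assay, with a plausible range from 10000 nM to 90000 nM.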

Compound 3, concentration for 50% growth inhibition: 23400 nM
Beside the measured number, compound 3's estimate is 1.3-fold (0.11 log units) above it; the range from low to high includes it.
By their numbers in this assay, from the lowest: compounds 2, 3 and 1 (each within the scatter of the next).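

Within the data shown here, replacing 3,4-dichlorophenyl with 4-fluorophenyl on the oxygen on an aromatic ring gives, in this assay, a 1.2-fold lower number from compound 1 to compound 3 (0.08 log units; within the scatter), which provides the first single-change reading and places compound 1 and compound 3 within the scatter of each other. At this position, therefore, going from two chlorine atoms to one fluorine atom on the six-membered carbon ring, with the total falling from 8 heavy atoms to 7, does not separate the two compounds by growth inhibition. No supporting measurement bears on this result, so nothing can be said about what lies behind it.

Among these compounds, this one step tests only two halogen-bearing phenyl groups, so it cannot show whether the position in general tolerates exchange or whether these two groups merely happen to give similar numbers. Still open, on these data alone, is whether a nitrile or a methoxy group on the phenyl ring, or a saturated alkyl chain in place of that ring, would give a step beyond the scatter.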